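The source may report more compounds than this note shows. Statements on the series, on what has been measured and on what is new or still open speak of the compounds shown alone.

Measured compounds:
Compound 1, `O=C(NCc1ccc(F)cc1)c1cc(Oc2ccc(/C=C/c3ccccn3)cc2)ccn1`, gives 45100 nM in a functional assay on HepG2 cells (Homo sapiens) for antiproliferative activity, read by CCK-8 assay, with a stated time of 48 h; on this read-out higher numbers stand for weaker inhibition and lower numbers for stronger inhibition.
Compound 2, `O=C(Nc1ccccc1)c1cc(Oc2ccc(/C=C/c3ccncc3)cc2)ccn1`, reaches only a limit of the assay, > 100000 nM, in this assay.
Compound 3, `COc1ccc(CNC(=O)c2cc(Oc3ccc(/C=C/c4ccncc4)cc3)ccn2)cc1`, likewise reaches only a limit of the assay, > 100000 nM, in this assay.

On these data alone, compound 3 therefore stands at the limit of > 100000 nM in this assay, at which 2 of the 3 values shown sit; its own result is a limit, not a number, so the true strength of its inhibition is unknown beyond that.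

The next compound, compound 4 with the structure `O=C(NCc1ccc(F)cc1)c1cc(Oc2ccc(/C=C/c3ccncc3)cc2)ccn1`, differs from compound 3 in one place: fluoro in place of methoxy on an aromatic carbon. Among the compounds with values here, only one measured step touches the amide-type nitrogen substituent, a step that the two limits leave unreadable from compound 2 to compound 3. Both ends of that step are limits, so its size cannot be read. Within the data shown here, no measured step swaps fluoro for methoxy on any ring. Among the measured compounds shown here, compound 1 carries the same 4-fluorobenzyl group and gives a number rather than a limit, but it differs from compound 4 elsewhere as well, and no step connects the two.

With so little to go on, the step of an at least 1.2-fold lower number from compound 3 to compound 4 (0.09 log units; that floor lies within the scatter) is expected to stay near the limit. Compound 4 is estimated at 80000 nM, within a range of 30000 nM to 200000 nM.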

Compound 4, half-maximal inhibitory concentration: 37200 nM
Compound 4: middle estimate off by 2.2-fold (0.33 log units), on the high side, within the range that was stated.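

In this assay, within the data shown here, 4-fluorobenzyl on the amide nitrogen gives the first readable number in this pyridin-4-yl series, with fluoro in place of methoxy on the aromatic ring giving an at least 2.6-fold lower number from compound 3 to compound 4 (0.42 log units; beyond the scatter). The change from phenyl on the same nitrogen gives an at least 2.6-fold lower number from compound 2 to compound 4 (0.42 log units; beyond the scatter); both steps start from a limit of the assay, so the true sizes could be larger. Moving the attachment of the pyridine ring makes no difference beyond the scatter, with pyridin-4-yl in place of pyridin-2-yl giving a 1.2-fold lower number from compound 1 to compound 4 (0.08 log units; within the scatter).

On these data alone, it remains open whether a plain benzyl group, with no ring substituent, would also give a readable number. Also open, as far as these compounds go, is how chloro, trifluoromethyl or an amine would compare with fluoro on that ring.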